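The compounds below may be only part of what the source reports. "The series", "measured", "known", "first", "only" and "open" are said of these compounds alone.

Working notes on the series. Compound 1 `C=CC1=C(C(=O)NCc2ccccc2)C(c2ccc(OC)cc2)OC1` gives 39500 nM in a functional assay on SW480 cells (Homo sapiens) for cytotoxicity, read by MTT assay, with a stated time of 24 h; on this read-out lower numbers stand for stronger inhibition and higher numbers for weaker inhibition. Compound 2 `C=CC1=C(C(=O)NCc2ccccc2)C(c2ccc(F)cc2)OC1` gives > 100000 nM in this assay, which is a limit of the assay and not a number (the limit of > 100000 nM in this assay, at which 1 of the 2 values shown sits). Among the measured compounds shown here, the single measured step, an at least 2.5-fold higher number from compound 1 to compound 2 (0.40 log units; beyond the scatter), is the whole record so far. Compound 3 `C=CC1=C(C(=O)NCc2ccccc2)C(c2ccc(Cl)c(Cl)c2)OC1` differs from compound 2 by 3,4-dichlorophenyl in place of 4-fluorophenyl on a saturated ring carbon. For the measured compounds named here, no measured step covers this change, so no move beyond the scatter is expected in this assay for compound 3, which is estimated at 90000 nM, in the range 30000 nM to 200000 nM. The expected step is an at least 1.1-fold lower number from compound 2 to compound 3 (0.04 log units; that floor lies within the scatter).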

Compound 3, half-maximal inhibitory concentration: > 100000 nM
Compound 3 was reported as a limit; the forecaster's own chance of this, stated with the estimate: 55%; middle value at least 1.1-fold (0.04 log units) away from the limit.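

In this assay compound 3 gives > 100000 nM, a limit of the assay and not a number. 3,4-Dichlorophenyl in place of 4-methoxyphenyl on the saturated ring carbon gives an at least 2.5-fold higher number from compound 1 to compound 3 (0.40 log units; beyond the scatter), a second step of this kind at this position, while the step between compound 2 and compound 3 cannot be read. Of the three compounds, only compound 1 gives a number rather than a limit: the limit of > 100000 nM in this assay, at which 2 of the 3 values shown sit.

Still open, on these data alone, is whether a 4-hydroxyphenyl or a 4-dimethylaminophenyl group on this carbon would give a number in this assay. As far as these compounds go, the order of compound 2 and compound 3 also remains open.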